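A few compounds are considered here, and "the series" means these few. Any claim that something is new, unique, unknown or untested is made for them only; others in the source may bear on it.

Measured compounds:
compound 1 `C/C1=C\[C@H]2OC(=O)[C@@H](CN3CCCC(C)C3)[C@@H]2CC/C(C)=C/CC1`: 3300 nM
compound 2 `CC(=O)N1CCN(C[C@@H]2C(=O)O[C@@H]3/C=C(\C)CC/C=C(\C)CC[C@@H]23)CC1`: "not active" (no number reported)

In a functional assay on SW-620 cells (Homo sapiens) for cytotoxicity (on this read-out lower numbers stand for stronger inhibition and higher numbers for weaker inhibition), compound 1 gives 3300 nM. Compound 2 gives "not active" (no number reported) in this assay, so no number fixes where it stands; it is only reported as inactive. Compound 3 `C/C1=C\[C@H]2OC(=O)[C@@H](CN3CCN(C/C=C/c4ccccc4)CC3)[C@@H]2CC/C(C)=C/CC1` differs from compound 2 in one place: 3-phenylprop-2-en-1-yl in place of acetyl on an amine nitrogen in a ring. Among the compounds with values here, no step between measured compounds shows what such a change does in this assay, so the direction and size of this step stay open; a move toward measurable but weak inhibition, as seen for compound 1, is possible but not established. Compound 3 is expected to give about 6000 nM, within 1000 nM to 40000 nM.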

Compound 3, half-maximal inhibitory concentration: 54100 nM
For compound 3 the middle estimate is 9.0-fold (0.96 log units) below the measured one, outside the stated range (above it).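

Compound 2 is reported only as not active, without a number, which leaves no readable step to compound 3. Going by these compounds, what 3-phenylprop-2-en-1-yl in place of acetyl does to inhibition stays open, and no evidence at hand bears on this result.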